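Extending the Alkyl Chain on an Aminotetrahydrofuran Core

This account rests on a few compounds, and the source may have more. Where it says the series, first, only, none or still open, it means among the compounds named here.

Compound 1, `CCCCCCCCNC[C@@H]1OC[C@H](N)[C@@H]1O`, carries an octyl chain on the amine attached to the shared core. In a functional assay on B16-F10 cells (Mus musculus) for antiproliferative activity, read by MTT assay, with a stated time of 72 h (a higher number here means a weaker inhibitor, a lower number a stronger inhibitor), compound 1 gives > 128000 nM, which is a limit of the assay rather than a measured number. Compound 2, `CCCCCCCCCCNC[C@@H]1OC[C@H](N)[C@H]1O`, bears a decyl chain on the same core and differs from compound 1 in stereochemistry. In this assay compound 2 likewise gives > 128000 nM, again a limit and not a number. Compound 1 therefore stands at the limit of > 128000 nM in this assay, at which 2 of the 2 values shown sit, and neither value allows any ordering between the two measured compounds. Compound 3, `CCCCCCCCCCCNC[C@@H]1OC[C@H](N)[C@@H]1O`, has not yet been measured in this assay, and it differs from compound 1 by propyl in place of hydrogen on a saturated chain carbon, eight bonds along the chain from an amine nitrogen. Among the compounds with values here, no step between measured compounds exists to calibrate the effect of this change in this assay, so the expectation rests on the two limits alone. With both measured compounds sitting at the same ceiling, compound 3 is expected at about 90000 nM, within 25000 nM to 300000 nM. The step of an at least 1.4-fold lower number from compound 1 to compound 3 (0.15 log units; that floor lies within the scatter) that this estimate means is expected to be at most a modest gain, quite possibly nothing beyond the scatter.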

Compound 3, half-maximal inhibitory concentration: 19300 nM
Compound 3: middle estimate off by 4.7-fold (0.67 log units), on the high side; the measured number lies below the stated range.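

In this assay, within the data shown here, replacing hydrogen with propyl on a saturated chain carbon, eight bonds along the chain from an amine nitrogen, gives an at least 6.6-fold lower number from compound 1 to compound 3 (0.82 log units; beyond the scatter), the first change in these compounds whose effect can be read at all. Its printed size is a floor and not an exact measure, as one end of the step is a limit of the assay. The lengthened chain of compound 3 gives a true number, 19300 nM. Compound 1 and compound 2 both remain at a limit of the assay, which is not a number: the limit of > 128000 nM in this assay, at which 2 of the 3 values shown sit.

The compounds shown leave open whether a still longer chain, such as a dodecyl or tetradecyl chain, would lower the number further or whether the gain would stop, and a single step cannot show how the effect depends on chain length. Compound 2 differs from compound 3 in both chain and stereochemistry, and its value is a limit, so the steps involving compound 2 cannot be read and the role of stereochemistry on the shared core stays unresolved.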